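The source may report more compounds than this note shows. Statements on the series, on what has been measured and on what is new or still open speak of the compounds shown alone.

Measured in an ADME assay on HEL cells (Homo sapiens) for cytotoxicity; a higher number here means that more compound is tolerated, a lower number that less compound is tolerated:
- compound 1 `CCOc1ccc(/C=N/NC(=O)COc2cccc3ccccc23)cc1O`: 18.1 ug/mL
- compound 2 `O=C(COc1cccc2ccccc12)N/N=C/C=C/c1ccccc1`: 100 ug/mL
- compound 3 `C/C(=N\NC(=O)COc1cccc2ccccc12)c1ccccc1Br`: 16.2 ug/mL

Compound 3 at 16.2 ug/mL sits within the scatter of compound 1 at 18.1 ug/mL. Compound 2 at 100 ug/mL lies beyond the scatter from compound 3.

Going by the values given here, compound 4 `C/C(=N\NC(=O)COc1cccc2ccccc12)c1ccccc1O` has no measurement yet. Its difference from compound 3 is hydroxy in place of bromo on an aromatic carbon. Among the compounds with values here, no measured pair isolates a single change, so the evidence is indirect. Compound 1, which carries a hydroxy group, gives 18.1 ug/mL, so no step beyond the scatter is expected in this assay. The estimated step of a 1.2-fold higher number from compound 3 to compound 4 (0.09 log units; within the scatter) stays within the scatter. For compound 4 the expected value is 20 ug/mL, with an estimated range of 8 ug/mL to 60 ug/mL.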

Compound 4, half-maximal cytotoxic concentration: 4 ug/mL
Compound 4: middle estimate off by 5.0-fold (0.70 log units), on the high side; the whole stated range lies above it.
By their numbers in this assay, from the lowest: compound 4; then compounds 3 and 1 (each within the scatter of the next); then compound 2.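

In this assay, going by these compounds alone, hydroxy in place of bromo on an aromatic carbon, ortho to a large group, gives a 4.1-fold lower number from compound 3 to compound 4 (0.61 log units; beyond the scatter) and is the only single-place change. Within the data shown here, it shows that the tolerated concentration responds to the group at this position, which the earlier compounds, differing in several places, could not show. Nothing at hand accounts for the step. On these data alone, whether it follows from hydroxy entering or bromo leaving stays open. An amine or a methoxy group at this same place would help separate the two.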